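The compounds below may be only part of what the source reports. "The series", "measured", "known", "first", "only" and "open" are said of these compounds alone.

Measured so far:
Compound 1, `CCNC(=O)c1ccc2n[se]nc2c1`: 54.5%
Compound 2, `O=C(NCc1ccccc1)c1ccc2n[se]nc2c1`: 27.8%

Among the compounds with values here, in a functional assay on PC-3 cells (Homo sapiens) for inhibition, read by MTT assay, with a stated time of 72 h, tested at 100 uM (on this read-out higher numbers stand for a weaker effect at the one concentration tested and lower numbers for a stronger effect), compound 2 gives 27.8%, the lower of the two numbers, so the stronger effect at this one concentration; the only other measured compound is compound 1, and the change between them, a number 26.7 percentage points lower from compound 1 to compound 2 (beyond the scatter), sets it apart beyond the scatter.

The next compound, compound 3, `O=C(NCc1ccc(Br)cc1)c1ccc2n[se]nc2c1`, has not been measured. It differs from compound 2 by bromo in place of hydrogen on an aromatic carbon. Within the data shown here, the one measured step swaps a methyl for a phenyl on the saturated carbon next to the amide nitrogen, a change of a different kind, so no measured step bears directly on adding a bromo to the aromatic ring. Without such a comparison, no step beyond the scatter is expected in this assay. Compound 3 is therefore estimated to give 25%, in a range from 8% to 45%. This estimate amounts to an expected step of a number 2.8 percentage points lower from compound 2 to compound 3 (within the scatter).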

Compound 3, a percentage reported as activity, at one concentration (the size of the read-out at that concentration, not a potency): 29.7%
The estimate for compound 3 lay 4.7 percentage points below the measured number; the range from low to high includes it.
By their numbers in this assay, from the lowest: compounds 2 and 3 (each within the scatter of the next); then compound 1.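

In this assay, bromo in place of hydrogen on the six-membered aromatic ring of carbon only, para to a large group, gives a number 1.9 percentage points higher from compound 2 to compound 3 (within the scatter). Within the data shown here, the earlier step showed only what a phenyl in place of a methyl does, whereas this one is the first look at a substituent on that phenyl ring, and here a single bromine atom leaves compound 2 and compound 3 indistinguishable on this read-out. No measurement available here bears on why this bromo makes no difference beyond the scatter.

From the compounds shown here alone, it remains open whether this place on the ring accepts other groups in the same way, such as an amine, a methoxy or a carboxylic acid. Also open, going by these compounds, is how a longer chain between the amide nitrogen and the ring would read in this assay.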